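Aryl versus alkyl on the imidazole nitrogen of the trimethoxyphenyl series

The source may report more compounds than this note shows. Statements on the series, on what has been measured and on what is new or still open speak of the compounds shown alone.

Measured compounds:
compound 1 `CCn1ccnc1-c1cc(OC)c(OC)c(OC)c1`, > 100000 nM
compound 2 `COc1cc(-c2nccn2Cc2ccccc2)cc(OC)c1OC`, > 100000 nM
compound 3 `COc1cc(-c2nccn2-c2ccc(F)cc2)cc(OC)c1OC`, 68600 nM

The three compounds share one core and differ only in the group carried on the aromatic nitrogen. In a functional assay on HCT-15 cells (Homo sapiens) for antiproliferative activity, read by MTT assay, with a stated time of 72 h (on this read-out higher numbers stand for weaker inhibition and lower numbers for stronger inhibition), compound 1 gives only a limit, > 100000 nM, and no number. Compound 2 likewise sits at a limit, > 100000 nM. Compound 3 is the only one of the three with a read number, 68600 nM. The steps to compound 3 are therefore floors: an at least 1.4-fold lower number from compound 1 to compound 3 (0.16 log units; that floor lies within the scatter), and an at least 1.4-fold lower number from compound 2 to compound 3 (0.16 log units; that floor lies within the scatter). The step that the two limits leave unreadable from compound 1 to compound 2 is unreadable, both values being limits (the limit of > 100000 nM in this assay, at which 2 of the 3 values shown sit).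

Compound 4 `COc1ccc(-n2ccnc2-c2cc(OC)c(OC)c(OC)c2)cc1` is to be measured in this assay. It differs from compound 1 as follows: 4-methoxyphenyl in place of ethyl on an aromatic nitrogen

Among the measured compounds shown here, the only measured step that bears on this change is the one to compound 3, in which an aromatic group likewise replaces the ethyl on the aromatic nitrogen, and there the number fell by at least the floor given. A step of similar kind, downward from compound 1 but modest, is expected for compound 4, an at least 1.6-fold lower number from compound 1 to compound 4 (0.22 log units; that floor lies within the scatter), with a fair chance that the assay again reports only a limit. Compound 4 is estimated at 60000 nM, between 15000 nM and 150000 nM.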

Compound 4, half-maximal inhibitory concentration: 1300 nM
Compound 4: the middle estimate sits 46-fold (1.66 log units) above what was measured; measured number below the stated range.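

In this assay, among the compounds shown here, the aromatic group on the nitrogen is not enough by itself, since what it carries decides the outcome: methoxy in place of fluoro gives a 53-fold lower number from compound 3 to compound 4 (1.72 log units; beyond the scatter), a change that the small floors among the earlier compounds gave no sign of. Compared with the ethyl and benzyl groups, 4-methoxyphenyl gives an at least 76-fold lower number from compound 1 to compound 4 (1.88 log units; beyond the scatter) and an at least 76-fold lower number from compound 2 to compound 4 (1.88 log units; beyond the scatter), so this position can carry a large change in the number and not just the modest one seen so far. Both of these steps are floors rather than sizes, as each starts from a limit: the limit of > 100000 nM in this assay, at which 2 of the 4 values shown sit.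

From the compounds shown here alone, whether the gain is held by other groups on that aromatic ring, such as hydroxy, ethoxy or dimethylamino, remains open. Going by these compounds, it is also open whether an unsubstituted phenyl on the aromatic nitrogen would read nearer to compound 3 or to compound 4, and so whether methoxy adds to the number or fluoro takes away from it.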